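The compounds below may be only part of what the source reports. "The series", "measured", "known", "first", "only" and "open" are said of these compounds alone.

Compounds measured so far: compound 1 `C=CC(=O)Nc1cc(C(F)(F)F)cc(C(F)(F)F)c1` with 1.8 h in an ADME assay for pharmacokinetics, read by LC-MS, in phosphate buffer, with a stated time of 72 h, at pH 7.4, tested at 250 uM; on this read-out lower numbers stand for a shorter-lived compound and higher numbers for a longer-lived compound; compound 2 `O=C1C=CC(=O)N1c1cc(C(F)(F)F)cc(C(F)(F)F)c1`; compound 3 `C#Cc1cc(C(F)(F)F)cc(C(F)(F)F)c1`. Compound 2 gives only a limit of this assay, < 0.017 h. Compound 3 likewise gives only a limit, > 50 h. Compound 2 thus stands at the short-lived end of the numbers shown, at the limit of < 0.017 h in this assay, at which 1 of the 3 values shown sits, while the other limit, (the limit of > 50 h in this assay, at which 1 of the 3 values shown sits), belongs to compound 3.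

The step to the unmeasured compound 4 `Fc1cc(C(F)(F)F)cc(C(F)(F)F)c1` is one fluorine atom in place of a group of 7 heavy atoms (4 carbon, 1 nitrogen, 2 oxygen; one five-membered non-aromatic ring with 1 hetero atom), on an aromatic carbon. The closest measured step removes the same seven-atom group: an at least 2900-fold higher number from compound 2 to compound 3 (3.46 log units; beyond the scatter), with ethynyl entering; an at least 100-fold lower number from compound 1 to compound 2 (2.02 log units; beyond the scatter) shows the same group arriving. A large rise is therefore expected, an at least 5800-fold higher number from compound 2 to compound 4 (3.76 log units; beyond the scatter). Compound 4 is estimated at 100 h, between 20 h and 500 h, and likely only a limit will be reported.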

Compound 4, half-life: > 50 h
Compound 4: a limit, no number; the forecaster's own chance of this, stated with the estimate: 80%; the middle value is on the limit's open side.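

In this assay compound 4 gives only a limit (> 50 h), the same limit that compound 3 reaches: the limit of > 50 h in this assay, at which 2 of the 4 values shown sit.
A long half-life on this aromatic carbon therefore does not depend on ethynyl, since fluoro also gives a large rise over both compounds that carry nitrogen there (an at least 2900-fold higher number from compound 2 to compound 4 (3.46 log units; beyond the scatter); an at least 27-fold higher number from compound 1 to compound 4 (1.44 log units; beyond the scatter)).
The two limits leave the step from compound 3 to compound 4 unreadable.

Which of fluoro and ethynyl gives the longer half-life stays open, as does the true half-life of either compound. Also open, going by these compounds, is where an amine or a carboxylic acid on this carbon would fall.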